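Ethoxy on the anilino group of compound 3

The compounds below may be only part of what the source reports. "The series", "measured", "known", "first", "only" and "open" are said of these compounds alone.

In a functional assay on HeLa cells (Homo sapiens) for antiproliferative activity, read by MTT assay, with a stated time of 72 h (a higher number here means a weaker inhibitor, a lower number a stronger inhibitor), compound 3 `COc1cc(C(=O)c2sc3ccccc3c2Nc2ccccc2)cc(OC)c1OC` gives 2700 nM. Compound 1 `COc1ccccc1-c1c(C(=O)c2cc(OC)c(OC)c(OC)c2)sc2ccccc12` gives 5000 nM, and the gap is a 1.9-fold lower number from compound 1 to compound 3 (0.27 log units; within the scatter). Compound 2 `COc1ccc(-c2c(C(=O)c3cc(OC)c(OC)c(OC)c3)sc3ccccc23)cc1C` gives 10000 nM, and the gap is a 3.7-fold lower number from compound 2 to compound 3 (0.57 log units; beyond the scatter). Compound 3 thus cannot be separated from compound 1 and has a clearly lower number only than compound 2.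

Compound 4 `CCOc1ccc(Nc2c(C(=O)c3cc(OC)c(OC)c(OC)c3)sc3ccccc23)cc1` differs by ethoxy in place of hydrogen on an aromatic carbon, para to a large group. Among the measured compounds shown here, no measured step isolates this change. The closest one, among aryl groups, is a 2.0-fold higher number from compound 1 to compound 2 (0.30 log units; within the scatter). A shift beyond the scatter is therefore not expected, and the expected step is a 1.4-fold lower number from compound 3 to compound 4 (0.13 log units; within the scatter). For compound 4 the estimate is 2000 nM, with an expected range of 400 nM to 8000 nM.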

Compound 4, half-maximal inhibitory concentration: 700 nM
Compound 4: middle estimate off by 2.9-fold (0.46 log units), on the high side, and the stated range covers the measured number.
By their numbers in this assay, from the lowest: compound 4; then compounds 3, 1 and 2 (each within the scatter of the next, the first and the last beyond it).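

In this assay, among the compounds shown here, ethoxy on an aromatic carbon of the anilino group, para to a large group, gives a step beyond the scatter (a 3.9-fold lower number from compound 3 to compound 4 (0.59 log units; beyond the scatter)), the first evidence that this position responds to substitution. (4-Ethoxyphenyl)amino also stands clear of both aryl groups (a 7.1-fold lower number from compound 1 to compound 4 (0.85 log units; beyond the scatter); a 14-fold lower number from compound 2 to compound 4 (1.15 log units; beyond the scatter)), whereas anilino stood clear only of 4-methoxy-3-methylphenyl. No available evidence bears on the reason for this shift.

Open, as far as these compounds go, is whether the shift is specific to ethoxy or would also follow from methoxy, a longer alkoxy chain or an amine at this place.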